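Three Values at the Limit and an Untested Aryl Change

The compounds below may be only part of what the source reports. "The series", "measured", "known", "first", "only" and "open" are said of these compounds alone.

Compound 1 `OC[C@H]1O[C@@H](n2cnc3c(NCc4ccc(Cl)cc4)ncnc32)[C@H](O)[C@@H]1O` in a functional assay on HOS cells (Homo sapiens) for antiproliferative activity, with a stated time of 72 h; on this read-out higher numbers stand for weaker inhibition and lower numbers for stronger inhibition: > 166000 nM, a limit of the assay rather than a number.
Compound 2 `OC[C@H]1O[C@@H](n2cnc3c(NCc4ccccc4Br)ncnc32)[C@H](O)[C@@H]1O`: > 166000 nM, again a limit of the assay.
Compound 3 `OC[C@H]1O[C@@H](n2cnc3c(NCc4cccc(Br)c4)ncnc32)[C@H](O)[C@@H]1O`: > 166000 nM, also a limit of the assay.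

Compound 3 thus stands where every shown value sits, at the limit of > 166000 nM in this assay, at which 3 of the 3 values shown sit, and nothing separates it from the other two. The steps a step that the two limits leave unreadable from compound 1 to compound 3 and a step that the two limits leave unreadable from compound 2 to compound 3 are accordingly without readable size. Compound 4 `COc1cccc(CNc2ncnc3c2ncn3[C@@H]2O[C@H](CO)[C@@H](O)[C@H]2O)c1O` carries 2-hydroxy-3-methoxyphenyl in place of 3-bromophenyl on a saturated chain carbon bound to a nitrogen on an aromatic ring. No measured step bears on a change of this kind, and since all shown values are limits, neither a direction nor a size can be read from them. The expected step in this assay is a step that the limit leaves unreadable from compound 3 to compound 4, which is to say no movement that the data could reveal. Compound 4 is therefore estimated at 200000 nM, with a range from 60000 nM to 600000 nM, most probably reported once more as a limit.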

Compound 4, half-maximal inhibitory concentration: > 166000 nM
Compound 4: a limit, no number (the forecaster's own chance of this, stated with the estimate: 85%); the middle value is on the limit's open side.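

Compound 4 also sits at a limit of the assay, so no step from compound 1, compound 2 or compound 3 to compound 4 can be read in this assay: the limit of > 166000 nM in this assay, at which 4 of the 4 values shown sit.

The compounds shown leave open whether any of these aryl groups differs from another in this read-out.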